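This account rests on a few compounds, and the source may have more. Where it says the series, first, only, none or still open, it means among the compounds named here.

Series notes. Compound 1 `COc1ccc2c(OCc3nnc4sc(-c5cc6cc(F)ccc6[nH]5)nn34)ccnc2c1` carries the shared core; in a functional assay on EBC-1 cells (Homo sapiens) for antiproliferative activity, with a stated time of 72 h (a lower number here means a stronger inhibitor, a higher number a weaker inhibitor), compound 1 gives "not determined" (no result reported), so it stands nowhere on the numbers gathered here and offers no anchor of its own. The measured members are compound 2 `COc1ccc(-c2nn3c(COc4ccnc5cc(OC)ccc45)nnc3s2)cc1`, which in this assay gives 161 nM, and compound 3 `COc1ccc2c(OCc3nnc4sc(-c5cc(F)c(F)c(F)c5)nn34)ccnc2c1`, which in this assay gives 403 nM. Going by the values given here, the one step between them, a 2.5-fold higher number from compound 2 to compound 3 (0.40 log units; beyond the scatter), shows that exchanging one aryl group on the shared core for another moves the number a modest amount and not more.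

Compound 4 `COc1ccc2c(OCc3nnc4sc(-c5ccn(CC6CC6)c5)nn34)ccnc2c1` differs from compound 1 on the shared core: 1-(cyclopropylmethyl)-1H-pyrrol-3-yl in place of 5-fluoro-1H-indol-2-yl on an aromatic carbon. Among the compounds with values here, no measured step covers this exchange. Within the data shown here, the step from compound 2 to compound 3 is the only guide, and it swaps one substituted phenyl for another, whereas here a 1-(cyclopropylmethyl)-1H-pyrrol-3-yl group replaces a 5-fluoro-1H-indol-2-yl group. Compound 1 has no number, so there is nothing to add a step to; the expectation for compound 4 can rest only on the band spanned by compound 2 and compound 3 and on the modest size of their step. Among the measured compounds shown here, compound 4 is therefore expected to land in this assay near 300 nM, within a range from 80 nM to 1200 nM, a deliberately wide band given that no measured pair covers this change.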

Compound 4, half-maximal inhibitory concentration: 351 nM
For compound 4 the middle estimate is 1.2-fold (0.07 log units) below the measured one, and the stated range covers the measured number.
By their numbers in this assay, from the lowest: compound 2; then compounds 4 and 3 (each within the scatter of the next).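

In this assay the position on the aromatic carbon next to the ring sulfur now reads beyond substituted phenyl groups: with 1-(cyclopropylmethyl)-1H-pyrrol-3-yl in place of 3,4,5-trifluorophenyl there is a 1.1-fold lower number from compound 3 to compound 4 (0.06 log units; within the scatter), so these two quite different groups cannot be told apart on this read-out. Against the 4-methoxyphenyl group the same entering group gives a 2.2-fold higher number from compound 2 to compound 4 (0.34 log units; beyond the scatter) and this is about the size of the step already seen between the two phenyl compounds, which leaves compound 2 with the lowest number of the three measured members and shows that a five-membered aromatic ring bearing a cyclopropylmethyl group costs no more here than the trifluorophenyl exchange did. Nothing in the data at hand accounts for these readings.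

The exchange from 5-fluoro-1H-indol-2-yl cannot be read, since compound 1 has no number, so the steps to compound 1 say nothing about the loss of the indole hydrogen-bond donor. Open too, on these data alone, is whether a longer chain such as n-butyl in place of the cyclopropylmethyl, or an amine or a carboxylic acid on the entering group, would move the number out of this narrow band.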